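From chloro to trifluoromethyl on compound 1

The source may report more compounds than this note shows. Statements on the series, on what has been measured and on what is new or still open speak of the compounds shown alone.

- Compound 1 `O=C(CC(c1ccccc1)c1ccccc1)N1CCN(C(c2ccccc2)c2cccc(Cl)c2)CC1` gives 2630 ng.h/mL
- Compound 2 `O=C(NC(c1ccccc1)c1ccccc1)N1CCN(C(c2ccccc2)c2ccccc2)CC1` gives 1290 ng.h/mL

In an ADME assay on the whole organism (plasma, strain Sprague-Dawley) for pharmacokinetics, with Rattus norvegicus as the target, with a stated time of 24 h, at a dose of 10 mg/kg by the oral route (a lower number here means less compound in the circulation, a higher number more compound in the circulation at the dose given), compound 1 holds the higher of the two numbers, and compound 2 lies below it by more than the usual scatter. Compound 3 (`O=C(CC(c1ccccc1)c1ccccc1)N1CCN(C(c2ccccc2)c2cccc(C(F)(F)F)c2)CC1`) has trifluoromethyl in place of chloro on an aromatic carbon, meta to a large group. Within the data shown here, no measured pair shows this change, so the expectation is uncertain: no step beyond the scatter, in either direction. The expected change is small (a 1.1-fold lower number from compound 1 to compound 3 (0.04 log units; within the scatter)). For compound 3 the estimated value is 2400 ng.h/mL (expected range 900 ng.h/mL to 6000 ng.h/mL).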

Compound 3, area under the concentration-time curve: 2470 ng.h/mL
Compound 3: the middle estimate sits 1.0-fold (0.01 log units) below what was measured; low and high end bracket the measured number.
By their numbers in this assay, from the lowest: compounds 2, 3 and 1 (each within the scatter of the next, the first and the last beyond it).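

In this assay, putting trifluoromethyl in place of chloro on this aromatic carbon gives a step within the usual scatter (a 1.1-fold lower number from compound 1 to compound 3 (0.03 log units; within the scatter)). This position therefore takes a group with more heavy atoms without a measurable difference in circulating compound, at least in this one pair. Nothing at hand explains why the two groups read alike. Still open, from the compounds shown here alone, is whether a methoxy group, an amine or a carboxylic acid at this place would also stay within the scatter of compound 1.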